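Sulfonamide-linked imidazolylpyrimidines: cytotoxicity notes

This account rests on a few compounds, and the source may have more. Where it says the series, first, only, none or still open, it means among the compounds named here.

Measured so far:
compound 1 `COc1ccc(S(=O)(=O)NCCCNc2nccc(-c3[nH]c(-c4ccccc4)nc3-c3ccc(F)c(OC)c3)n2)cc1`: 6130 nM
compound 2 `COc1cc(-c2nc(-c3ccccc3)[nH]c2-c2ccnc(NCCCNS(=O)(=O)c3cccc4ccccc34)n2)ccc1F`: 14900 nM
compound 3 `COc1ccc(S(=O)(=O)NCCCNc2nccc(-c3[nH]c(-c4ccccc4)nc3-c3ccc(F)c(O)c3)n2)cc1`: 13900 nM

All three were run in a functional assay on LOX IMVI cells (Homo sapiens) for cytotoxicity, read by MTT assay, with a stated time of 24 h; on this read-out higher numbers stand for weaker inhibition and lower numbers for stronger inhibition. Compound 1 is the anchor. Compound 2 differs from it by naphthalen-1-yl in place of 4-methoxyphenyl on a sulfonyl sulfur, which gave a 2.4-fold higher number from compound 1 to compound 2 (0.39 log units; beyond the scatter). Compound 3 differs from it by hydrogen in place of methyl on an oxygen on an aromatic ring, which gave a 2.3-fold higher number from compound 1 to compound 3 (0.36 log units; beyond the scatter). Compound 2 and compound 3 sit within the scatter of each other.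

Compound 4 `O=S(=O)(NCCCNc1nccc(-c2[nH]c(-c3ccccc3)nc2-c2ccc(F)c(O)c2)n1)c1cccc2ccccc12` is not yet measured. It differs from compound 3 by naphthalen-1-yl in place of 4-methoxyphenyl on a sulfonyl sulfur, the same change as from compound 1 to compound 2, made on a core that differs by hydrogen in place of methyl on an oxygen on an aromatic ring. The step from compound 3 to compound 4 in this assay is expected to be about a 2.4-fold higher number from compound 3 to compound 4 (0.38 log units; beyond the scatter), resting on the single earlier case, a 2.4-fold higher number from compound 1 to compound 2 (0.39 log units; beyond the scatter). Compound 4 is therefore estimated at 33000 nM, with the range 15000 nM to 75000 nM.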

Compound 4, half-maximal inhibitory concentration: 3710 nM
For compound 4 the middle estimate is 8.9-fold (0.95 log units) above the measured one; measured number outside the range, below it.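

In this assay, naphthalen-1-yl in place of 4-methoxyphenyl on a sulfonyl sulfur gives a 3.7-fold lower number from compound 3 to compound 4 (0.57 log units; beyond the scatter), opposite in direction to the earlier step: the same change on two cores in this assay, a 2.4-fold higher number (0.39 log units; beyond the scatter) from compound 1 to compound 2 and a 3.7-fold lower number (0.57 log units; beyond the scatter) from compound 3 to compound 4, 9.1-fold (0.96 log units) apart, beyond the scatter of two such steps. Hydrogen in place of methyl on the oxygen gives a 4.0-fold lower number from compound 2 to compound 4 (0.60 log units; beyond the scatter), which is also reversed: the same change on two cores in this assay, a 2.3-fold higher number (0.36 log units; beyond the scatter) from compound 1 to compound 3 and a 4.0-fold lower number (0.60 log units; beyond the scatter) from compound 2 to compound 4, 9.1-fold (0.96 log units) apart, beyond the scatter of two such steps. Neither change carries over unaltered from one core to the other here, and the two do not add, but these four compounds show neither why this happens nor whether it holds across the series.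

On these data alone, whether the reversal persists with a plain phenyl or a methyl on the sulfonyl sulfur, or with an amine in place of the hydroxyl, stays open. As far as these compounds go, whether it appears in other cell lines also stays open.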